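Cytotoxicity series: fluoro for trifluoromethyl on the core

The source may hold more compounds than are shown below. What is called first, only, known or untested is meant among the compounds shown, and "the series" means these compounds.

Working notes on a small set sharing one core. Compound 1 `CS(=O)(=O)CCCn1c(Cn2c(=O)n(C3CC3)c3ccncc32)nc2nc(Cl)ccc21` is tested in an ADME assay on HeLa cells (Homo sapiens) for cytotoxicity, read by ATP content, with a stated time of 3 days; on this read-out lower numbers stand for higher toxicity in this test and higher numbers for lower toxicity in this test; compound 1 reaches only the limit of the assay, > 50000 nM. Compound 2 `CS(=O)(=O)CCCn1c(Cn2c(=O)n(C3CC3)c3ccncc32)cc2cc(C(F)(F)F)ccc21` likewise reaches only a limit in this assay, > 50000 nM. Compound 3 `N#CCCCn1c(Cn2c(=O)n(-c3ccc(OC(F)(F)F)cc3)c3ccncc32)cc2cc(Cl)ccc21` also returns only a limit in this assay, > 50000 nM. Among the measured compounds shown here, compound 2 therefore stands at the limit of > 50000 nM in this assay, at which 3 of the 3 values shown sit, so no ordering among the three is possible and no step between measured compounds can be stated.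

Compound 4 `CS(=O)(=O)CCCn1c(Cn2c(=O)n(C3CC3)c3ccncc32)cc2cc(F)ccc21` has not yet been tested in this assay. It differs from compound 2 in one place: fluoro in place of trifluoromethyl on an aromatic carbon. Nothing in the measurements distinguishes the substituent at that place, since every compound shown sits at the same limit. The expectation is therefore no step beyond the scatter, with an expected step of a number no higher from compound 2 to compound 4 (the limit leaves the size open) from compound 2 to compound 4. For compound 4 the estimate in this assay is 50000 nM, within a range of 30000 nM to 100000 nM, most likely reported again as a limit.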

Compound 4, half-maximal cytotoxic concentration: > 50000 nM
Compound 4 ended at the assay's limit (the forecaster's own chance of this, stated with the estimate: 85%); the middle value lies on the limit itself.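

Compound 2 and compound 4 both return only a limit of the assay, so no step can be read for fluoro in place of trifluoromethyl. The compounds shown leave open whether any change on the shared core gives a measurable cytotoxic concentration.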